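Working notes: propyl in place of ethoxy

A few compounds are considered here, and "the series" means these few. Any claim that something is new, unique, unknown or untested is made for them only; others in the source may bear on it.

Measured in a functional assay on M14 cells (Homo sapiens) for cytotoxicity; a higher number here means a weaker inhibitor of growth, a lower number a stronger inhibitor of growth:
- compound 1 `CCc1ccc(/N=C/c2cc(OC)c(OC)c(OC)c2)cc1`: > 100000 nM (a limit)
- compound 2 `COc1ccc(/N=C/c2cc(OC)c(OC)c(OC)c2)cc1`: 83800 nM
- compound 3 `CCOc1ccc(/N=C/c2cc(OC)c(OC)c(OC)c2)cc1`: > 100000 nM (a limit)

Compound 3 is known only as a limit, > 100000 nM. It shares that position with one other compound, as the limit of > 100000 nM in this assay, at which 2 of the 3 values shown sit, shows. The open compound is compound 4 `CCCc1ccc(/N=C/c2cc(OC)c(OC)c(OC)c2)cc1`. The change is propyl in place of ethoxy on an aromatic carbon, para to a large group.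

For the measured compounds named here, three measured steps bear on this. The nearest exchange, ethoxy in place of ethyl, gives a step that the two limits leave unreadable from compound 1 to compound 3. Methoxy in place of ethyl gives an at least 1.1-fold lower number from compound 1 to compound 2 (0.07 log units; that floor lies within the scatter). Adding the methyl to the methoxy gives an at least 1.1-fold higher number from compound 2 to compound 3 (0.07 log units; that floor lies within the scatter). Neither floor lies beyond the scatter, and no readable step supports a size or direction for the change.

No step beyond the scatter is therefore expected in this assay. The expectation leans on compound 1 at > 100000 nM, which is also a limit and carries a simple chain in the same place. The expected change is a step that the limit leaves unreadable from compound 3 to compound 4. A report at the limit is the likeliest outcome. For compound 4 the estimated value is 120000 nM, with an expected range from 60000 nM to 250000 nM.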

Compound 4, concentration for 50% growth inhibition: > 100000 nM
Compound 4: no number, only a limit; the forecaster's own chance of this, stated with the estimate: 75%; the middle value is on the limit's open side.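

Compound 4 adds propyl to ethyl and ethoxy at this aromatic carbon, and in this assay all three compounds carrying these groups stand at one limit of the assay, not at a number: the limit of > 100000 nM in this assay, at which 3 of the 4 values shown sit. Removing the oxygen from a substituent of this heavy-atom count therefore does not bring a readable value, as the ethoxy of compound 3 and the propyl of compound 4 cannot be told apart. Propyl in place of methoxy gives an at least 1.1-fold higher number from compound 2 to compound 4 (0.07 log units; that floor lies within the scatter), so this step shows no change beyond the scatter, and the steps from compound 3 and compound 1 to compound 4 cannot be read, with limits at both ends.

The compounds shown leave open where compound 1, compound 3 and compound 4 lie past the limit, so no order among them can be given. They also leave open whether an amine or a carboxylic acid at this aromatic carbon would give a number lying clearly beyond the scatter from that of compound 2.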